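Demethylation of a Chloro Naphthoquinone and Its Effect on Cytotoxicity

The compounds below may be only part of what the source reports. "The series", "measured", "known", "first", "only" and "open" are said of these compounds alone.

Three chlorinated naphthoquinones carrying a methyl group and an oxygen substituent on the aromatic ring have been measured, and a fourth awaits measurement. Compound 1 `Cc1cc(Cl)c2c(c1O)C(=O)C=CC2=O` bears a free hydroxy group, while compound 2 `COc1c(C)cc(Cl)c2c1C(=O)C=CC2=O` carries the corresponding methoxy group. In a functional assay on DU-145 cells (Homo sapiens) for cytotoxicity, read by XTT assay, with a stated time of 24 h (a lower number here means a stronger inhibitor, a higher number a weaker inhibitor), compound 1 gives 9300 nM, and compound 2 gives 36500 nM. The change from compound 2 to compound 1 is hydrogen in place of methyl on an oxygen on an aromatic ring, and it produced a 3.9-fold lower number from compound 2 to compound 1 (0.59 log units; beyond the scatter).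

Compound 3 `COc1cc(C)c(Cl)c2c1C(=O)C=CC2=O` is built from the same atoms as compound 2, joined differently; the difference between the two cores is not broken down here. In this assay compound 3 gives 26600 nM, a value within the scatter of that of compound 2 and higher than that of compound 1.

Compound 4 `Cc1cc(O)c2c(c1Cl)C(=O)C=CC2=O` stands to compound 3 as compound 1 stands to compound 2: the change is hydrogen in place of methyl on an oxygen on an aromatic ring, the same change that was seen between compound 2 and compound 1, occurring here on the other core. Because the earlier step gave a 3.9-fold lower number from compound 2 to compound 1 (0.59 log units; beyond the scatter), a step of comparable size is expected from compound 3 to compound 4, a 3.5-fold lower number from compound 3 to compound 4 (0.55 log units; beyond the scatter), although this rests on a single measured example. On that basis compound 4 is expected to give 7500 nM in this assay, with a plausible range from 3000 nM to 20000 nM.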

Compound 4, half-maximal inhibitory concentration: 29500 nM
Compound 4: middle estimate off by 3.9-fold (0.59 log units), on the low side; the whole stated range lies below it.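

Methoxy to hydroxy gave a 1.1-fold higher number from compound 3 to compound 4 (0.04 log units; within the scatter) in this assay, so on the core of compound 3 this change produced no shift that can be told from the usual variation between repeated measurements. This shows that the lower number seen on the core of compound 1 cannot be assumed to carry over to the other core, even though the two cores are built from the same atoms and the change itself is identical. It does not show why the two cores part ways, and with only one pair on each core it gives no general rule for the series or for any other change, only that the size of this step depended on the core in these two cases: the same change on two cores in this assay, a 3.9-fold lower number (0.59 log units; beyond the scatter) from compound 2 to compound 1 and a 1.1-fold higher number (0.04 log units; within the scatter) from compound 3 to compound 4, 4.4-fold (0.64 log units) apart, beyond the scatter of two such steps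

The compounds shown carry only hydroxy or methoxy at the changing place, so it remains open whether an ethoxy group, a longer alkoxy chain or an amine there would follow the behaviour of the one core or of the other. On these data alone, it also remains open whether a group such as bromine or a carboxylic acid elsewhere on these cores would alter the difference between the two steps.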